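A Hydroxyphenyl Swap on a Weak Growth Inhibitor

The compounds below may be only part of what the source reports. "The series", "measured", "known", "first", "only" and "open" are said of these compounds alone.

Compound 1 `COc1ccccc1/C=C(/SCc1ccc(Cl)c(Cl)c1)C(=O)c1ccc(Cl)cc1` is one of three close relatives tested for how strongly they hold back the growth of a prostate cancer cell line. In a functional assay on DU-145 cells (Homo sapiens) for inhibition, read by trypan blue exclusion, with a stated time of 96 h (a lower number here means a stronger inhibitor of growth, a higher number a weaker inhibitor of growth), compound 1 gives 10000 nM. Compound 3 `O=C(/C(=C\c1ccccc1OCc1ccccc1)SCc1ccc(Cl)c(Cl)c1)c1ccc(Cl)cc1` gives 10000 nM in this assay, so compound 1 and compound 3 sit together at the weakest end of the three numbers. Compound 2 `COc1ccccc1/C=C(/SCc1ccc(Cl)cc1)C(=O)c1ccc(Cl)cc1` gives 1000 nM in this assay, and the step from a 10-fold lower number from compound 1 to compound 2 (1.00 log units; beyond the scatter) comes from hydrogen in place of chloro on an aromatic carbon.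

Compound 4 `O=C(/C(=C\c1ccc(O)cc1)SCc1ccc(Cl)c(Cl)c1)c1ccc(Cl)cc1` differs from compound 1 in one place: 4-hydroxyphenyl in place of 2-methoxyphenyl on a double-bonded chain carbon bound to a double-bonded chain carbon. The step that bears most on this change is no change at the digits printed from compound 1 to compound 3 (within the scatter), where the same aryl group on the shared core was altered at its oxygen and the number stayed put. The step from compound 1 to compound 2 concerns a different part of the molecule and does not speak to this change. On that basis, little movement beyond the scatter is expected, and for compound 4 the estimate is 10000 nM, within 3000 nM to 30000 nM, meaning an expected step of no change at the digits printed from compound 1 to compound 4 (within the scatter).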

Compound 4, concentration for 50% growth inhibition: 1000 nM
Compound 4: middle estimate off by 10-fold (1.00 log units), on the high side; the measured number lies below the stated range.
By their numbers in this assay, from the lowest: compounds 2 and 4 (each within the scatter of the next); then compounds 1 and 3 (each within the scatter of the next).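

The aryl group on a double-bonded chain carbon bound to a double-bonded chain carbon can clearly move the growth-inhibition number: the swap to 4-hydroxyphenyl gives a 10-fold lower number from compound 1 to compound 4 (1.00 log units; beyond the scatter), whereas the earlier change at the oxygen of this group gave no change at the digits printed from compound 1 to compound 3 (within the scatter). The flat result for compound 3 therefore does not mean that every change to this aryl group leaves the number unchanged, and the new step also adds a hydrogen-bond donor, as the count for 4-hydroxyphenyl shows. No measurement available here accounts for the shift.

The swap alters both the group on the oxygen and the place of the oxygen on the ring, so the compounds shown cannot separate the two. On these data alone, whether an amine or a carboxylic acid in place of the hydroxyl would keep this gain also remains open.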